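Working notes: a substituent change at the ether chain carbon

The compounds below may be only part of what the source reports. "The series", "measured", "known", "first", "only" and "open" are said of these compounds alone.

Measured compounds:
compound 1 `Cc1ccnc([C@@H](C)Oc2cc3oc(=O)n(CCC(=O)O)c3cc2Cl)c1` gives 3.98 nM in an assay for inhibition of kynurenine 3-monooxygenase (Homo sapiens), read by mass spectrometry, with a stated time of 1 h; a lower number here means a stronger inhibitor, a higher number a weaker inhibitor
compound 2 `CCOc1cc2oc(=O)n(CCC(=O)O)c2cc1Cl` gives 5.01 nM in this assay
compound 3 `O=C(O)CCn1c(=O)oc2cc(OCC3CCC3)c(Cl)cc21` gives 25.1 nM in this assay

Compound 2 sits second highest of the three numbers in this assay. Its nearest neighbour is compound 1, with a 1.3-fold higher number from compound 1 to compound 2 (0.10 log units; within the scatter), a gap inside the scatter. The furthest is compound 3, reached by a 5.0-fold higher number from compound 2 to compound 3 (0.70 log units; beyond the scatter), a modest step beyond the scatter.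

Compound 4 `Cc1cccc([C@@H](C)Oc2cc3oc(=O)n(CCC(=O)O)c3cc2Cl)n1` differs from compound 2 in one place: 6-methylpyridin-2-yl in place of hydrogen on a saturated chain carbon bound to an oxygen on an aromatic ring and a saturated chain carbon.

Going by the values given here, the step that bears on this change is the one between compound 1 and compound 2, where a 4-methylpyridin-2-yl on the same saturated chain carbon is exchanged for hydrogen: a 1.3-fold higher number from compound 1 to compound 2 (0.10 log units; within the scatter), within the scatter. The change to compound 4 puts a 6-methylpyridin-2-yl at that same place, a close relative of what compound 1 carries. The step from compound 2 to compound 3 concerns a different part of the structure and does not bear on it. No step beyond the scatter is therefore expected in this assay, in either direction.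

Compound 4 is estimated at 4.5 nM in this assay, with a range of 2 nM to 10 nM, which is expected to mean a 1.1-fold lower number from compound 2 to compound 4 (0.05 log units; within the scatter).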

Compound 4, half-maximal inhibitory concentration: 5.01 nM
Compound 4: middle estimate off by 1.1-fold (0.05 log units), on the low side; measured number inside the range.
By their numbers in this assay, from the lowest: compounds 1, 2 and 4 (each within the scatter of the next); then compound 3.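

In this assay, putting 6-methylpyridin-2-yl on the saturated chain carbon bound to an oxygen on an aromatic ring and a saturated chain carbon gives no change at the digits printed from compound 2 to compound 4 (within the scatter), so this place accepts a second aromatic group of 7 heavy atoms with no step beyond the scatter against hydrogen. Exchanging 4-methylpyridin-2-yl for 6-methylpyridin-2-yl gives a 1.3-fold higher number from compound 1 to compound 4 (0.10 log units; within the scatter), so the two methylpyridinyl groups cannot be told apart in this assay, and the placing of the methyl on the ring shows no effect beyond the scatter in these two compounds. Nothing in hand accounts for this flat response at the position.

The compounds shown leave open whether the nitrogen of the 6-methylpyridin-2-yl matters at this place, which a plain phenyl group on the same saturated chain carbon would address. They also leave open whether this tolerance extends beyond methylpyridinyl groups, for instance to a primary amine or a carboxylic acid at that carbon.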